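Methyl to trifluoromethyl on the core: expectation for compound 4

This account rests on a few compounds, and the source may have more. Where it says the series, first, only, none or still open, it means among the compounds named here.

Measured compounds:
compound 1 `CNc1nc(C)c(C(=O)N/N=C/c2cccc(C(F)(F)F)c2)s1`: > 100 ug/mL
compound 2 `CN(C(=O)NC(=O)c1c(F)cccc1F)c1nc(C(F)(F)F)c(C(=O)N/N=C/c2cccc(C(F)(F)F)c2)s1`: 21.6 ug/mL
compound 3 `Cc1nc(N(C)C(=O)NC(=O)c2c(F)cccc2F)sc1C(=O)N/N=C/c1cccc(C(F)(F)F)c1`: 26.8 ug/mL

In a functional assay on HeLa cells (Homo sapiens) for inhibition, read by MTT assay, with a stated time of 72 h (on this read-out lower numbers stand for stronger inhibition and higher numbers for weaker inhibition), compound 1 gives > 100 ug/mL, which is a limit of the assay and not a number; compound 1 sits at the limit of > 100 ug/mL in this assay, at which 1 of the 3 values shown sits. In this assay compound 3 gives 26.8 ug/mL and compound 2 gives 21.6 ug/mL. The change trifluoromethyl in place of methyl on an aromatic carbon made a 1.2-fold lower number from compound 3 to compound 2 (0.09 log units; within the scatter).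

Compound 4 `CNc1nc(C(F)(F)F)c(C(=O)N/N=C/c2cccc(C(F)(F)F)c2)s1` carries the same kind of change on the core of compound 1, (trifluoromethyl in place of methyl on an aromatic carbon); around the place the ring atom two ring bonds away bears a methylamino group (2 heavy atoms) rather than a large group. How the cores of compound 1 and compound 3 differ is not broken down here.

Because a 1.2-fold lower number from compound 3 to compound 2 (0.09 log units; within the scatter) lies within the scatter, the step of a number no higher from compound 1 to compound 4 (the limit leaves the size open) is expected to be small, and compound 4 is expected to sit near the limit as well. For compound 4 the estimate in this assay is 100 ug/mL, expected between 50 ug/mL and 200 ug/mL.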

Compound 4, half-maximal inhibitory concentration: > 100 ug/mL
Compound 4: only a limit was reported; the forecaster's own chance of this, stated with the estimate: 70%; the middle value sits exactly at the limit.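

No step can be read from compound 1 to compound 4, since both give a limit of the assay and not a number: the limit of > 100 ug/mL in this assay, at which 2 of the 4 values shown sit.

The compounds shown leave open how trifluoromethyl in place of methyl acts on this core.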